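Acetyl on the ring amine: cytotoxicity in HEL cells

The source may report more compounds than this note shows. Statements on the series, on what has been measured and on what is new or still open speak of the compounds shown alone.

Measured so far:
compound 1 `Cc1ccc(-[n+]2noc([O-])c2CN2CCN(c3cccc(Cl)c3)CC2)cc1` — 100 ug/mL
compound 2 `Cc1ccc(-[n+]2noc([O-])c2CN2CCNCC2)cc1` — 100 ug/mL

Two compounds have been run in an ADME assay on HEL cells (Homo sapiens) for cytotoxicity; on this read-out higher numbers stand for lower toxicity in this test and lower numbers for higher toxicity in this test. Compound 1 gives 100 ug/mL, and compound 2, in which hydrogen replaces 3-chlorophenyl on an amine nitrogen in a ring, gives 100 ug/mL; the step of no change at the digits printed from compound 1 to compound 2 (within the scatter) lies within the scatter, so compound 2 stands level with compound 1.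

Compound 3 `CC(=O)N1CCN(Cc2c([O-])on[n+]2-c2ccc(C)cc2)CC1` has not been measured yet. It differs from compound 2 in one place: acetyl in place of hydrogen on an amine nitrogen in a ring. Among the measured compounds shown here, the only measured step touches the same amine nitrogen in a ring, and removing the whole 3-chlorophenyl group there left this assay unchanged, so an acetyl entering at that nitrogen is expected to change little. The step of no change at the digits printed from compound 2 to compound 3 (within the scatter) is expected to stay within the scatter. Compound 3 is therefore estimated at 100 ug/mL, with a range from 50 ug/mL to 200 ug/mL.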

Compound 3, minimum cytotoxic concentration: 100 ug/mL
For compound 3 middle estimate and measured number coincide at the digits printed; low and high end bracket the measured number.
By their numbers in this assay, from the lowest: compounds 1, 2 and 3 (each within the scatter of the next).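

In this assay, putting acetyl on the amine nitrogen in the ring gives no change at the digits printed from compound 2 to compound 3 (within the scatter), and exchanging 3-chlorophenyl for acetyl at the same nitrogen gives no change at the digits printed from compound 1 to compound 3 (within the scatter). Among the compounds shown here, until now this position had been seen only with hydrogen and an aromatic ring; acetyl adds a small group with no ring and a carbonyl, and the read-out still does not separate the three compounds. Nothing available here explains why these different groups give matching values.

From the compounds shown here alone, whether a carboxylic acid, an amine or a longer chain on this nitrogen would also match these values remains open. These compounds also cannot say whether a change elsewhere on the shared core would leave the read-out just as unmoved.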